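This account rests on a few compounds, and the source may have more. Where it says the series, first, only, none or still open, it means among the compounds named here.

Measured compounds: compound 1, `Cc1ccc2nc(/N=C3\C(=O)N(CN(C)C)c4cccc(Br)c43)sc2c1`, gives 49000 nM; compound 2, `CN(C)CN1C(=O)C(=O)c2c(Br)cccc21`, gives 93700 nM.

Both numbers come from a functional assay on MDA-MB-231 cells (Homo sapiens) for cytotoxicity, read by sulforhodamine B assay, with a stated time of 48 h; on this read-out higher numbers stand for weaker inhibition of growth and lower numbers for stronger inhibition of growth. Of the two, the number of compound 2 is numerically the higher, but its gap to compound 1 lies within the usual scatter, so the two cannot be set apart on this evidence; compound 1 carries a large fused substituent on the core that compound 2 lacks, and even so the read-outs of the two fall close together.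

Compound 3, `O=C1C(=O)N(CN2CCCCC2)c2cccc(Br)c21`, has not yet been measured in this assay. It differs from compound 2 in one place: piperidin-1-yl in place of dimethylamino on a saturated chain carbon bound to an amide-type nitrogen in a ring. For the measured compounds named here, no measured pair shows this exchange, so there is no step to draw on. Since the two measured compounds sit close together despite a far larger difference between them, the expected step of a 1.3-fold lower number from compound 2 to compound 3 (0.13 log units; within the scatter) is none beyond the scatter. Compound 3 is therefore estimated at 70000 nM, with a range from 25000 nM to 200000 nM.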

Compound 3, concentration for 50% growth inhibition: 30200 nM
The estimate for compound 3 lay 2.3-fold (0.37 log units) above the measured number, within the range that was stated.
By their numbers in this assay, from the lowest: compounds 3, 1 and 2 (each within the scatter of the next, the first and the last beyond it).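

In this assay, piperidin-1-yl in place of dimethylamino on a saturated chain carbon bound to an amide-type nitrogen in a ring gives a 3.1-fold lower number from compound 2 to compound 3 (0.49 log units; beyond the scatter) and so takes the read-out beyond the scatter. For the compounds shown here, this is the first sign that the read-out depends on the group at this place, since compounds 1 and 2 differ elsewhere and their numbers could not be set apart. The counts of hydrogen-bond donors and acceptors are the same in the two groups, and the exchange alters the heavy-atom count and adds a ring without altering those counts. Nothing in the data explains the step.

On these data alone, whether the step comes from the ring itself or simply from the added carbon atoms stays open, and a pyrrolidin-1-yl or morpholin-4-yl group, or an open diethylamino group, at the same place would help to separate the two. As far as these compounds go, it also remains open whether the same exchange would give a step of similar size on the core of compound 1, with its large fused substituent.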